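From a Branched to a Straight Ester Chain

The source may report more compounds than this note shows. Statements on the series, on what has been measured and on what is new or still open speak of the compounds shown alone.

Within the data shown here, in an ADME assay on Vero cells (Chlorocebus sabaeus) for cytotoxicity, read by reporter gene assay, with a stated time of 4 days (a lower number here means a stronger inhibitor, a higher number a weaker inhibitor), compound 3 (`CCCC(C)C(=O)OCC(C)(C)CC1=C(O)C(=O)c2ccccc2C1=O`) gives 120 nM, the lowest number so far. The amides compound 1 (`CCCC(C)C(=O)NCC(C)(C)CC1=C(O)C(=O)c2ccccc2C1=O`) at 48100 nM and compound 2 (`CCCCCC(=O)NCC(C)(C)CC1=C(O)C(=O)c2ccccc2C1=O`) at 46600 nM sit far higher, as a 400-fold lower number from compound 1 to compound 3 (2.60 log units; beyond the scatter) and a 390-fold lower number from compound 2 to compound 3 (2.59 log units; beyond the scatter) show. Compound 4 (`CCCCCCC(=O)OCC(C)(C)CC1=C(O)C(=O)c2ccccc2C1=O`) keeps the ester of compound 3 and differs by hexyl in place of 1-methylbutyl on a carbonyl carbon. Among the measured compounds shown here, the nearest precedent is a 1.0-fold lower number from compound 1 to compound 2 (0.01 log units; within the scatter), within the scatter, though it comes from the amide pair alone. The large steps concern a change compound 4 does not make, so no step beyond the scatter is expected in this assay. The expected step is a 1.3-fold higher number from compound 3 to compound 4 (0.10 log units; within the scatter). Compound 4 is estimated at 150 nM, with a range of 40 nM to 600 nM.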

Compound 4, half-maximal inhibitory concentration: 99300 nM
The estimate for compound 4 lay 660-fold (2.82 log units) below the measured number; the measured number lies above the stated range.
By their numbers in this assay, from the lowest: compound 3; then compounds 2 and 1 (each within the scatter of the next); then compound 4.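

In this assay, hexyl in place of 1-methylbutyl on a carbonyl carbon gives an 830-fold higher number from compound 3 to compound 4 (2.92 log units; beyond the scatter), a large step on the ester where the amide pair showed none. The ester alone therefore does not secure the low number: with hexyl, the comparison with the amides reads a 2.1-fold higher number from compound 2 to compound 4 (0.33 log units; beyond the scatter) and a 2.1-fold higher number from compound 1 to compound 4 (0.31 log units; beyond the scatter), modest steps upward. No measurement at hand explains this reversal.

Open, as far as these compounds go, is whether the low number of compound 3 follows the branch of 1-methylbutyl or the chain length, and how an ester carrying a pentyl or a heptyl chain would read.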